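The source may hold more compounds than are shown below. What is called first, only, known or untested is meant among the compounds shown, and "the series" means these compounds.

Series notes. All three measured compounds carry the same core, an amide of a dichloro-dihydroxy-tetrahydroisoquinoline, and differ only in the acyl chain. Compound 1 `O=C(/C=C/c1ccccc1)N1CCc2c(Cl)c(O)c(O)c(Cl)c2C1` carries a cinnamoyl-type chain; in a functional assay (Homo sapiens), tested at 10 uM (a lower number here means a stronger effect, a higher number a weaker effect of the compound at the concentration tested), compound 1 gives 41%. Compound 2 `O=C(CCCc1ncc(C(F)(F)F)cc1Cl)N1CCc2c(Cl)c(O)c(O)c(Cl)c2C1` carries a saturated three-carbon chain ending in a chloro-trifluoromethyl-pyridyl and gives 5%. Compound 3 `O=C(CCCc1ncc(C(F)(F)F)cc1C1CCCCC1)N1CCc2c(Cl)c(O)c(O)c(Cl)c2C1` is the cyclohexyl analogue of compound 2; compound 3 gives 77%. On these numbers compound 1 stands second highest of three, set off from compound 2 as well as from compound 3 by steps beyond the scatter. Among the measured compounds shown here, the one step, a number 72 percentage points higher from compound 2 to compound 3 (beyond the scatter), concerns a substituent on the pyridyl ring of the saturated chain and is large.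

Compound 4 `O=C(/C=C/c1ccc(F)cn1)N1CCc2c(Cl)c(O)c(O)c(Cl)c2C1` is the next compound: 5-fluoropyridin-2-yl in place of phenyl on a double-bonded chain carbon bound to a double-bonded chain carbon. For the measured compounds named here, no measured step concerns an exchange of the aromatic ring at the end of the unsaturated chain, so the step from compound 2 to compound 3 bears only loosely on it and gives no direction. Without a direct precedent, the expectation for compound 4 is a step of a number 1 percentage points lower from compound 1 to compound 4 (within the scatter), that is, no step beyond the scatter. The estimate for compound 4 is therefore 40%, with a range from 18% to 65%.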

Compound 4, a percentage reported as activity, at one concentration (the size of the read-out at that concentration, not a potency): 24%
Beside the measured number, compound 4's estimate is 16 percentage points above it; the measured number falls inside the stated range.
By their numbers in this assay, from the lowest: compound 2; then compound 4; then compound 1; then compound 3.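

The end of the unsaturated chain proves to be a position that responds to change: in this assay the exchange of phenyl for 5-fluoropyridin-2-yl gives a number 17 percentage points lower from compound 1 to compound 4 (beyond the scatter) and thus a stronger effect at the concentration tested. Among the compounds shown here, until now, the only measured step lay on the pyridyl ring of the saturated chain, so this is the first reading for the aromatic ring of the unsaturated chain, and it shows that this ring need not be carbon only. For the compounds shown here, the change brings in a ring nitrogen and a fluorine together, so the single step cannot be divided between them, and nothing available here accounts for its size or direction.

Open, from the compounds shown here alone, is which of the two entering atoms carries the step, a question that an unsubstituted pyridyl or a fluorophenyl on the same unsaturated chain would settle. Also open, going by these compounds, is whether the step depends on the double bond, which the same 5-fluoropyridin-2-yl on a saturated three-carbon chain would test.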